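From pyridin-2-yl to 8-hydroxyquinolin-2-yl on a shared core

The compounds below may be only part of what the source reports. "The series", "measured", "known", "first", "only" and "open" are said of these compounds alone.

In a functional assay on K562 cells (Homo sapiens) for inhibition, read by trypan blue exclusion, with a stated time of 72 h (a lower number here means a stronger inhibitor, a higher number a weaker inhibitor), compound 1 `Cn1c(=O)c(S(=O)(=O)c2ccc(F)cc2F)cc2cnc(Nc3ccc4occc4c3)nc21` gives 15000 nM. Compound 2 `Cn1c(=O)c(S(=O)(=O)c2ccc(F)cc2F)cc2cnc(Nc3ccccn3)nc21` gives 35000 nM, the higher of the two numbers, which makes it the weaker inhibitor of the pair. Compound 3 `Cn1c(=O)c(S(=O)(=O)c2ccc(F)cc2F)cc2cnc(Nc3ccc4cccc(O)c4n3)nc21` keeps the same core but has 8-hydroxyquinolin-2-yl in place of pyridin-2-yl on a nitrogen on an aromatic ring.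

Among the compounds with values here, only one measured step changes this same place: a 2.3-fold higher number from compound 1 to compound 2 (0.37 log units; beyond the scatter). Within the data shown here, this modest step is the sole guide, and no measured compound carries a hydroxy group, so the evidence is thin. Going by a 2.3-fold higher number from compound 1 to compound 2 (0.37 log units; beyond the scatter), replacing pyridin-2-yl is expected to give a modest move to a lower number in this assay. The expected change is a 2.3-fold lower number from compound 2 to compound 3 (0.37 log units; beyond the scatter). The estimate for compound 3 is 15000 nM, within a range of 5000 nM to 40000 nM.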

Compound 3, half-maximal inhibitory concentration: 5000 nM
The estimate for compound 3 lay 3.0-fold (0.48 log units) above the measured number; measured number inside the range.
By their numbers in this assay, from the lowest: compound 3; then compound 1; then compound 2.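

In this assay the step of a 7.0-fold lower number from compound 2 to compound 3 (0.85 log units; beyond the scatter) is larger than the first step seen at this position, so this place on the shared core has more room for change than the first two compounds suggested. The 8-hydroxyquinolin-2-yl group also beats the 1-benzofuran-5-yl group, with a 3.0-fold lower number from compound 1 to compound 3 (0.48 log units; beyond the scatter) as the step, which makes compound 3 the strongest inhibitor of the three. Nothing shown here explains this gain.

The change brings in a further aromatic ring of carbon only and a hydroxy group together, and the compounds shown cannot separate the part each one plays. A plain quinolin-2-yl group, or a methoxy or an amine in place of the hydroxy group, would be the comparison that begins to tell them apart.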